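Swapping Chloro for Fluoro on Compound 2

The compounds below may be only part of what the source reports. "The series", "measured", "known", "first", "only" and "open" are said of these compounds alone.

Of the compounds shown here, two have been measured so far. In a functional assay on BGC-823 cells (Homo sapiens) for inhibition, read by CCK-8 assay, with a stated time of 48 h (on this read-out lower numbers stand for stronger inhibition and higher numbers for weaker inhibition), compound 1 `Fc1ccc(C2=NN(C3=NC(c4ccccc4)CS3)C(c3cccc4ccccc34)C2)cc1` gives 22700 nM and compound 2 `O=C1CSC(N2N=C(c3ccc(Cl)cc3)CC2c2cccc3ccccc23)=N1` gives 16400 nM. These two values lie within the usual scatter of each other, so compound 2 cannot be told apart from compound 1 on these numbers. Compound 3 `O=C1CSC(N2N=C(c3ccc(F)cc3)CC2c2cccc3ccccc23)=N1` is compound 2 with one change: fluoro in place of chloro on an aromatic carbon. This is fluoro in place of chloro on an aromatic carbon, so 4-chlorophenyl becomes 4-fluorophenyl. Going by the values given here, no measured pair shows this swap alone. Compound 1 also carries 4-fluorophenyl, although it differs from compound 2 elsewhere, and compound 1 gives 22700 nM. The expected step of a 1.1-fold higher number from compound 2 to compound 3 (0.04 log units; within the scatter) therefore stays within the scatter, with no clear direction. For compound 3 the estimated value is 18000 nM, with an expected range from 9000 nM to 36000 nM.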

Compound 3, half-maximal inhibitory concentration: 19300 nM
Beside the measured number, compound 3's estimate is 1.1-fold (0.03 log units) below it; the range from low to high includes it.
By their numbers in this assay, from the lowest: compounds 2, 3 and 1 (each within the scatter of the next).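

In this assay, fluoro in place of chloro alone gives a 1.2-fold higher number from compound 2 to compound 3 (0.07 log units; within the scatter) on this aromatic carbon, so 4-chlorophenyl and 4-fluorophenyl cannot be told apart here. Going by these compounds alone, this is the first pair to isolate that swap, since compound 1 and compound 2 differ in more than one place. A second one-place comparison, on the amine nitrogen in a ring, gives a 1.2-fold lower number from compound 1 to compound 3 (0.07 log units; within the scatter) when the group of compound 3 stands in place of the group of compound 1, and this too cannot be told apart; nothing measured alongside these compounds bears on what lies behind either result.

On these data alone, all three compounds carry a halogen on this phenyl ring, so the effect of an amine, a methoxy group or a carboxylic acid at this position remains open. As far as these compounds go, whether any group there can move the number beyond the scatter also remains unknown.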